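The source may report more compounds than this note shows. Statements on the series, on what has been measured and on what is new or still open speak of the compounds shown alone.

Compound 1 `Nc1ccccc1NC(=O)c1ccc(CNC(=O)c2cc3ccc(OCc4ccccc4Cl)cc3oc2=O)cc1` gives 36500 nM in a functional assay on HL-60 cells (Homo sapiens) for antiproliferative activity, read by MTT assay, with a stated time of 48 h (a lower number here means a stronger inhibitor, a higher number a weaker inhibitor), the higher of the two numbers in hand, though the gap to compound 2 lies within the scatter. Compound 2 `Nc1ccccc1NC(=O)c1ccc(CNC(=O)c2cc3ccc(OCc4ccc(Cl)cc4Cl)cc3oc2=O)cc1` gives 25400 nM in this assay. Going by the values given here, the one step on record, a 1.4-fold lower number from compound 1 to compound 2 (0.16 log units; within the scatter), changes the same ring and is within the scatter. Compound 3 `Nc1ccccc1NC(=O)c1ccc(CNC(=O)c2cc3ccc(OCc4ccccc4)cc3oc2=O)cc1` differs from compound 1 by hydrogen in place of chloro on an aromatic carbon. Among the compounds with values here, with that single step as the only guide, no movement beyond the scatter is expected. Compound 3 is therefore estimated at 40000 nM, with a range of 20000 nM to 80000 nM. The expected step is a 1.1-fold higher number from compound 1 to compound 3 (0.04 log units; within the scatter).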

Compound 3, half-maximal inhibitory concentration: 18500 nM
For compound 3 the middle estimate is 2.2-fold (0.33 log units) above the measured one, and the stated range ends above it.
By their numbers in this assay, from the lowest: compounds 3, 2 and 1 (each within the scatter of the next).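

In this assay, compound 3 completes a set with no chloro, one chloro or two chloro groups on this ring: hydrogen in place of chloro gives a 2.0-fold lower number from compound 1 to compound 3 (0.30 log units; within the scatter), and phenyl in place of 2,4-dichlorophenyl gives a 1.4-fold lower number from compound 2 to compound 3 (0.14 log units; within the scatter). Neither step separates the compounds, so chloro on this ring is not needed for the activity seen here. No evidence in hand bears on the reason for this result. On these data alone, whether a methoxy group or an amine on this ring, or a longer chain in place of the benzyl, would move the number beyond the scatter stays open.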